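A few compounds are considered here, and "the series" means these few. Any claim that something is new, unique, unknown or untested is made for them only; others in the source may bear on it.

Compound 1 `CCOc1ccccc1-c1ccc(-c2nc3cnccc3c(N[C@H](CC)C(N)=O)c2C#N)cc1` gives 3 in a physicochemical assay for lipophilicity, read by HPLC, at pH 7.5; a higher number here means a more lipophilic compound, a lower number a more polar compound.
Compound 2 `CCOc1ccccc1-c1ccc(-c2nc3cnccc3c(N[C@H](CC)C(=O)NS(=O)(=O)C3CC3)c2C#N)cc1` gives 2.3 in this assay.
Compound 3 `CCOc1ccccc1-c1ccc(-c2nc3cnccc3c(NC(C)C(=O)O)c2C#N)cc1` gives 2.1 in this assay.

Compound 3 has the lowest of these three numbers: compound 2 lies close to it, within the scatter, while compound 1 sits further off, beyond the scatter. Compound 4 `CCOc1ccccc1-c1ccc(-c2nc3cnccc3c(NC(CC)CNS(=O)(=O)C3CC3)c2C#N)cc1` differs from compound 3 in one place: a group of 11 heavy atoms (7 carbon, 1 nitrogen, 2 oxygen, 1 sulfur; one three-membered non-aromatic ring of carbon only) in place of a group of 5 heavy atoms (3 carbon, 2 oxygen; no ring), on a nitrogen on an aromatic ring. Within the data shown here, the steps that bear on this change are a number 0.90 log units lower from compound 1 to compound 3 (beyond the scatter) and a number 0.20 log units lower from compound 2 to compound 3 (within the scatter), alongside a number 0.70 log units lower from compound 1 to compound 2 (beyond the scatter). Since every measured step toward compound 3 went downward, a move away from compound 3 in this assay is expected to go upward, by a modest step of about a number 1.30 log units higher from compound 3 to compound 4 (beyond the scatter). Compound 4 is therefore estimated at 3.4 in this assay, with a range from 2.7 to 4.1.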

Compound 4, distribution coefficient: 3.6
Beside the measured number, compound 4's estimate is 0.20 log units below it; the range from low to high includes it.
By their numbers in this assay, from the lowest: compounds 3 and 2 (each within the scatter of the next); then compound 1; then compound 4.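

In this assay, this position now reaches above compound 1 as well as below it, with a number 0.60 log units higher from compound 1 to compound 4 (beyond the scatter). The groups entering in compound 2 and compound 4 share their carbon, nitrogen and sulfur counts and differ only in oxygen, yet the step is large, at a number 1.30 log units higher from compound 2 to compound 4 (beyond the scatter), and it is of the same order as a number 1.50 log units higher from compound 3 to compound 4 (beyond the scatter). So a small difference in atom count at this place can go with a large step.

Nothing given here accounts for these steps. On these data alone, what an amine or a hydroxyl group on this nitrogen's chain would give remains open.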